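The source may hold more compounds than are shown below. What is called first, only, known or untested is meant among the compounds shown, and "the series" means these compounds.

Compound 2 `Cc1ccccc1CNc1nc(N)nc(-c2ccccc2CO)n1` stands highest of the two measured compounds: in a functional assay on cells for positive allosteric modulation of G-protein coupled receptor 68 (Homo sapiens), read by a luciferase reporter and cAMP accumulation, with a stated time of 30 min, at pH 6.8 and pH 8.3, in the presence of a further agent that is not named here (on this read-out higher numbers stand for higher potency (the scale is a negative logarithm) and lower numbers for lower potency), compound 2 gives 4.7, while compound 1 `Nc1nc(NCc2ccccc2F)nc(-c2ccccc2CO)n1` gives 4.27. Among the measured compounds shown here, the only measured step, a number 0.43 log units higher from compound 1 to compound 2 (beyond the scatter), concerns a different change, methyl in place of fluoro on an aromatic carbon. Compound 3 `COc1ccc(CNc2nc(N)nc(-c3ccccc3CO)n2)cc1` differs from compound 2 by 4-methoxyphenyl in place of 2-methylphenyl on a saturated chain carbon bound to a nitrogen on an aromatic ring. For the measured compounds named here, no measured step bears directly on this change, so a step of about the same size as before, in either direction, or none beyond the scatter, is possible. The expected step is a number 0.20 log units lower from compound 2 to compound 3 (within the scatter), giving for compound 3 an estimated 4.5, between 3.9 and 5.1.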

Compound 3, negative logarithm of the antagonist equilibrium constant: 3.34
Compound 3: middle estimate off by 1.16 log units, on the high side; the measured number lies below the stated range.
By their numbers in this assay, from the lowest: compound 3; then compound 1; then compound 2.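

In this assay putting 4-methoxyphenyl in place of 2-methylphenyl on this saturated chain carbon gives a number 1.36 log units lower from compound 2 to compound 3 (beyond the scatter) and so moves the number much further than swapping fluoro for methyl did. Measured against 2-fluorophenyl, the same group gives a number 0.93 log units lower from compound 1 to compound 3 (beyond the scatter) and thus falls short of both earlier groups. Nothing available explains this drop.

The new group differs from the earlier ones in both its substituent and where that substituent sits. The effects of the two remain tangled. Results for 2-methoxyphenyl and 4-methylphenyl would help separate them.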